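Swapping methyl for bromo on a potent cytotoxic hydroxamic acid

The compounds below may be only part of what the source reports. "The series", "measured", "known", "first", "only" and "open" are said of these compounds alone.

Measured in a functional assay on NCI-H23 cells (Homo sapiens) for cytotoxicity, read by colorimetric assay; a lower number here means a stronger inhibitor, a higher number a weaker inhibitor:
Compound 1 `Cc1ccc2c(c1)/C(=C1/Nc3ccccc3/C1=N\O)C(=O)N2Cc1ccc(/C=C/C(=O)NO)cc1` gives 10 nM
Compound 2 `Cc1ccc2c(c1)/C(=C1/Nc3ccccc3/C1=N\O)C(=O)N2Cc1ccc(C(=O)NO)cc1` gives 10 nM

Among the compounds with values here, compound 1 stands level with compound 2, the only other measured compound. Compound 3 `O=C(/C=C/c1ccc(CN2C(=O)/C(=C3\Nc4ccccc4\C3=N/O)c3cc(Br)ccc32)cc1)NO` has bromo in place of methyl on an aromatic carbon of the core of compound 1 (bromo in place of methyl on an aromatic carbon). Within the data shown here, the one measured step, no change at the digits printed from compound 1 to compound 2 (within the scatter), stays within the scatter, but it changes the hydroxycarbamoyl side chain and leaves the methyl untouched. Among the measured compounds shown here, it bears on this change only indirectly, and no measured step varies that methyl. In this assay the estimated step of no change at the digits printed from compound 1 to compound 3 (within the scatter) is expected to stay within the scatter, in neither direction. Compound 3 is expected at 10 nM, with an estimated range of 4 nM to 25 nM.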

Compound 3, half-maximal inhibitory concentration: 9 nM
Compound 3: the middle estimate sits 1.1-fold (0.05 log units) above what was measured; measured number inside the range.
By their numbers in this assay, from the lowest: compounds 3, 1 and 2 (each within the scatter of the next).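

In this assay, within the data shown here, the step of a 1.1-fold lower number from compound 1 to compound 3 (0.05 log units; within the scatter) is the first to vary this aromatic carbon of the core, and it stays within the scatter, so bromo and methyl cannot be told apart here on the 2-(hydroxycarbamoyl)ethenyl side chain. The earlier step had changed only that side chain. No supporting evidence is available to explain this result. From the compounds shown here alone, whether a methoxy group or an amine at this carbon would give a similar value remains open, as does whether bromo would behave likewise with the hydroxycarbamoyl side chain of compound 2.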